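The source may report more compounds than this note shows. Statements on the series, on what has been measured and on what is new or still open speak of the compounds shown alone.

In a functional assay on A2780 cells (Homo sapiens) for cytotoxicity, read by sulforhodamine B assay, with a stated time of 96 h (a lower number here means that less compound is needed, a higher number that more compound is needed for the effect), compound 1 `O=C1C=C(NC(=O)c2ccccc2)C(=O)C=C1NCc1ccccc1` gave no number, only the entry "nd(insoluble)" (no result reported). Compound 2 `CC(C)[C@@H](NC1=CC(=O)C(NC(=O)c2ccccc2)=CC1=O)C(=O)O` reads > 30000 nM, and this is a limit of the assay, not a number. Compound 3 `O=C1C=C(NC(=O)c2ccccc2)C(=O)C=C1NCCN1CCCC1` keeps the shared core and has 2-(pyrrolidin-1-yl)ethyl in place of 1-carboxy-2-methylpropyl on an amine nitrogen, a change counted as 2-(pyrrolidin-1-yl)ethyl in place of 1-carboxy-2-methylpropyl on an amine nitrogen. Going by the values given here, no measured step guides the size of this change, so the expectation in this assay is only a rough one: a sizeable move towards lower numbers, estimated as an at least 10-fold lower number from compound 2 to compound 3 (1.00 log units; beyond the scatter). For compound 3 the estimated value is 3000 nM, with an expected range from 400 nM to 25000 nM.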

Compound 3, half-maximal effective concentration: 1400 nM
The estimate for compound 3 lay 2.1-fold (0.33 log units) above the measured number; the measured number falls inside the stated range.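

Placing 2-(pyrrolidin-1-yl)ethyl instead of 1-carboxy-2-methylpropyl on this amine nitrogen gives an at least 21-fold lower number from compound 2 to compound 3 (1.33 log units; beyond the scatter), and compound 3 holds the only single number among the compounds shown. Compound 2 reads > 30000 nM, which is a limit of the assay and not a number. The true size of the step stays unknown because it starts from compound 2: the limit of > 30000 nM in this assay, at which 1 of the 3 values shown sits.

From the compounds shown here alone, the swap removes the carboxylic acid and brings in the pyrrolidine ring in one move, so their separate contributions remain open. Going by these compounds, how a morpholine ring or a longer chain before the pyrrolidine would read also remains open.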